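A few compounds are considered here, and "the series" means these few. Any claim that something is new, unique, unknown or untested is made for them only; others in the source may bear on it.

Compound 2 `OC[C@H]1OC(n2cnc3c(-c4cc[nH]c4)ncnc32)[C@H](O)[C@@H]1O` and compound 1 `OC[C@H]1OC(n2cnc3c(-c4cc[nH]n4)ncnc32)[C@H](O)[C@@H]1O` share the same core and differ only in the five-membered ring attached to it. In a functional assay on L1210 cells (Mus musculus) for inhibition (on this read-out higher numbers stand for weaker inhibition and lower numbers for stronger inhibition), compound 1 gives 19800 nM, while compound 2 gives 17500 nM. The step of a 1.1-fold lower number from compound 1 to compound 2 (0.05 log units; within the scatter) is too small to count as a real difference, so compound 2 simply stands at one of two numbers that sit close together. Compound 3 `OC[C@H]1OC(n2cnc3c(-c4ccc(O)cc4)ncnc32)[C@H](O)[C@@H]1O` carries a different ring at that same point: 4-hydroxyphenyl in place of 1H-pyrrol-3-yl on an aromatic carbon. Among the measured compounds shown here, no measured step covers this kind of exchange; the only step in hand, a 1.1-fold lower number from compound 1 to compound 2 (0.05 log units; within the scatter), swaps one five-membered ring for another and shows essentially no movement. Without a step of the same kind to lean on, the expectation is that compound 3 lands near compound 2, with the new ring possibly moving the number in either direction but probably not far. Compound 3 is therefore estimated at 15000 nM in this assay, with a plausible range from 5000 nM to 50000 nM. That estimate means an expected step of a 1.2-fold lower number from compound 2 to compound 3 (0.07 log units; within the scatter), essentially flat.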

Compound 3, half-maximal inhibitory concentration: 5000 nM
The estimate for compound 3 lay 3.0-fold (0.48 log units) above the measured number; the range from low to high includes it.
By their numbers in this assay, from the lowest: compound 3; then compounds 2 and 1 (each within the scatter of the next).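

Among the compounds shown, the exchange between the two five-membered rings barely moved the number in this assay, with a 1.1-fold lower number from compound 1 to compound 2 (0.05 log units; within the scatter), but this position does respond when a six-membered ring is placed on it. Putting 4-hydroxyphenyl in place of 1H-pyrrol-3-yl gives a 3.5-fold lower number from compound 2 to compound 3 (0.54 log units; beyond the scatter), and putting it in place of 1H-pyrazol-3-yl gives a 4.0-fold lower number from compound 1 to compound 3 (0.60 log units; beyond the scatter), so both steps are modest but real, and compound 3 has the lowest number of the three, meaning the strongest inhibition on this read-out. Nothing available explains why this exchange moves the number.

The new group differs from the old ones in two ways at once, a larger all-carbon ring and a hydroxyl on it, so these compounds cannot say which of the two carries the step; a plain phenyl ring would separate them. Also open, from the compounds shown here alone, is how the number would respond if the hydroxyl gave way to a methoxy group, an amine or a carboxylic acid on that phenyl ring.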